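Carboxy to hydroxymethyl on the compound 1 core

The source may report more compounds than this note shows. Statements on the series, on what has been measured and on what is new or still open speak of the compounds shown alone.

Measured in an ADME assay on TZM cells (Homo sapiens) for cytotoxicity, read by XTT assay, with a stated time of 4 days; on this read-out lower numbers stand for higher toxicity in this test and higher numbers for lower toxicity in this test:
- compound 1 `Cc1cc(CCC#N)cc(C)c1Oc1cc(Nc2ccc(C#N)cc2)c(N)cc1C(=O)O`: 14300 nM
- compound 2 `Cc1cc(/C=C/C#N)cc(C)c1Oc1cc(Nc2ccc(C#N)cc2)c(N)cc1C(N)=O`: > 23600 nM (a limit)
- compound 3 `CC(=O)/C=C/c1cc(C)c(Oc2cc(Nc3ccc(C#N)cc3)c(N)cc2C(F)(F)F)c(C)c1`: > 8600 nM (a limit)

Among the measured compounds shown here, compound 1 holds the only true number in this assay, at 14300 nM. The other two values are limits and not numbers, so compound 1 cannot be ranked against them.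

The next compound to be read is compound 4 `Cc1cc(CCC#N)cc(C)c1Oc1cc(Nc2ccc(C#N)cc2)c(N)cc1CO`. It keeps the core of compound 1 and carries hydroxymethyl in place of carboxy on an aromatic carbon, para to a (4-cyanophenyl)amino group (hydroxymethyl in place of carboxy on an aromatic carbon).

For the measured compounds named here, no pair of measured compounds differs in one place only, so no measured step bears on this change. With compound 1 at 14300 nM as the sole anchor, no step beyond the scatter is expected in this assay, and no direction is favoured. The expected result is a 1.2-fold lower number from compound 1 to compound 4 (0.08 log units; within the scatter).

The estimate for compound 4 is 12000 nM, with an expected range from 3500 nM to 40000 nM.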

Compound 4, half-maximal cytotoxic concentration: > 23800 nM
Compound 4 ended at the assay's limit; the forecaster's own chance of this, stated with the estimate: 40%; middle value at least 1.9-fold (0.29 log units) away from the limit.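

In this assay, among the compounds shown here, this is the first step that differs in one place only, and it comes from replacing carboxy with hydroxymethyl on an aromatic carbon, para to a (4-cyanophenyl)amino group. The result is an at least 1.6-fold higher number from compound 1 to compound 4 (0.22 log units; that floor lies within the scatter); this is a floor and not a measured size, and it shows no fall in the number on the core of compound 1. Compound 4 gives a limit and not a number: the limit of > 23800 nM in this assay, at which 1 of the 4 values shown sits.

The true distance between compound 4 and compound 1 stays open, as does any cause for the step. For the compounds shown here, also open is how an aminomethyl group or a methyl ester at this position would read in this assay, and whether the same change holds with a chain other than the one on compound 1.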